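A few compounds are considered here, and "the series" means these few. Any claim that something is new, unique, unknown or untested is made for them only; others in the source may bear on it.

Values in a functional assay on MCF7 cells (Homo sapiens) for antiproliferative activity, with a stated time of 5 days (on this read-out lower numbers stand for stronger inhibition and higher numbers for weaker inhibition), so far
- compound 1 (`COc1ccc(-c2[nH]c3ccc(F)cc3c2C=C(C#N)C#N)cc1`) gives 310 nM
- compound 2 (`COc1ccc(-c2[nH]c3ccc(C)cc3c2C=C(C#N)C#N)cc1`) gives 200 nM
- compound 3 (`COc1ccc(-c2[nH]c3cc(Cl)c(C)cc3c2C=C(C#N)C#N)cc1`) gives 200 nM

Compound 3 and compound 2 stand level at 200 nM and compound 1 lies within the scatter of both. The next compound, compound 4 (`CCCCc1ccc2[nH]c(-c3ccc(OC)cc3)c(C=C(C#N)C#N)c2c1`), departs from compound 2 by propyl in place of hydrogen on a saturated chain carbon bound to an aromatic carbon and the same difference, cut one bond further out, reads methyl to butyl.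

Within the data shown here, two measured steps bear on this change, and only indirectly. Methyl in place of fluoro on an aromatic carbon gave a 1.6-fold lower number from compound 1 to compound 2 (0.19 log units; within the scatter) and chloro in place of hydrogen on an aromatic carbon gave no change at the digits printed from compound 2 to compound 3 (within the scatter) so neither step leaves the scatter. Among the measured compounds shown here, no measured compound carries butyl, so the series offers no direct measure of this extension and the uncertainty stays wide. The expectation in this assay is therefore no step beyond the scatter, with a slight lean toward a lower number taken from the direction of a 1.6-fold lower number from compound 1 to compound 2 (0.19 log units; within the scatter) alone. The expected change is a 1.5-fold lower number from compound 2 to compound 4 (0.19 log units; within the scatter) on this estimate. Compound 4 is expected at 130 nM with an estimated range from 35 nM to 450 nM on this read-out.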

Compound 4, half-maximal inhibitory concentration: 13 nM
Estimate against measurement, compound 4: 10-fold (1.00 log units) above; measured number outside the range, below it.
By their numbers in this assay, from the lowest: compound 4; then compounds 2, 3 and 1 (each within the scatter of the next).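

In this assay, the position carrying the methyl of compound 2 proves sensitive to the group placed there: the change from methyl to butyl gives a 15-fold lower number from compound 2 to compound 4 (1.19 log units; beyond the scatter), and butyl in place of fluoro gives a 24-fold lower number from compound 1 to compound 4 (1.38 log units; beyond the scatter). The earlier steps shown here at or near this part of the series did not show such sensitivity, as a 1.6-fold lower number from compound 1 to compound 2 (0.19 log units; within the scatter) and no change at the digits printed from compound 2 to compound 3 (within the scatter) both stay within the scatter. These two steps show that a butyl chain at this place is not merely tolerated but goes with a large drop in the number, though no accompanying measurement offers an account of that drop.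

Whether the number depends on chain length in a graded way remains open, since ethyl, a longer chain such as hexyl and a branched chain such as tert-butyl do not appear among the compounds shown. Also open, on these data alone, is whether the chain must remain purely hydrocarbon at this place, or whether one ending in an amine or a carboxylic acid would hold the number of compound 4 at 13 nM.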